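The source may report more compounds than this note shows. Statements on the series, on what has been measured and on what is new or still open speak of the compounds shown alone.

Of the compounds shown here, three built on one shared core have been tested in an ADME assay on HeLa cells (Homo sapiens) for cytotoxicity; a lower number here means a stronger inhibitor, a higher number a weaker inhibitor. Compound 1 `Cc1ncc([N+](=O)[O-])n1CCSC(=S)N1CCC(C)CC1` gives 190 ug/mL. Compound 2 `Cc1ncc([N+](=O)[O-])n1CCSC(=S)N1CCC(OC(=O)CSC(=S)N2CCCCC2)CC1` gives 980 ug/mL. Compound 3 `Cc1ncc([N+](=O)[O-])n1CCSC(=S)N1CCC(OC(=O)CCl)CC1` gives 930 ug/mL. Of these three numbers compound 3 holds the second highest; compound 2 lies nearest, within the scatter of it, while compound 1 lies furthest away, beyond the scatter. Compound 4 `Cc1ncc([N+](=O)[O-])n1CCSC(=S)N1CCC(OC(=O)CN2CCCCC2)CC1` differs from compound 3 by piperidin-1-yl in place of chloro on a saturated chain carbon bound to a carbonyl carbon. Going by the values given here, two measured steps bear on this change. The step of a 4.9-fold higher number from compound 1 to compound 3 (0.69 log units; beyond the scatter) shows the effect of placing the ((chloromethyl)carbonyl)oxy group on the saturated ring carbon. The step of a 1.1-fold lower number from compound 2 to compound 3 (0.02 log units; within the scatter) shows that exchanging the chlorine atom at this same carbon for a much larger ring-containing group left the number essentially where it was. Because the step of a 1.1-fold lower number from compound 2 to compound 3 (0.02 log units; within the scatter) stayed within the scatter, the step of a 1.0-fold lower number from compound 3 to compound 4 (0.01 log units; within the scatter) is expected to stay within the scatter as well. Compound 4 is therefore estimated at 900 ug/mL, with a range from 450 ug/mL to 1800 ug/mL.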

Compound 4, half-maximal inhibitory concentration: 760 ug/mL
The estimate for compound 4 lay 1.2-fold (0.07 log units) above the measured number; the measured number falls inside the stated range.
By their numbers in this assay, from the lowest: compound 1; then compounds 4, 3 and 2 (each within the scatter of the next).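

In this assay, the step of a 1.2-fold lower number from compound 3 to compound 4 (0.09 log units; within the scatter) adds a third kind of group on the saturated chain carbon bound to a carbonyl carbon, and the step of a 1.3-fold lower number from compound 2 to compound 4 (0.11 log units; within the scatter) confirms that chloro, piperidin-1-yl and the larger group of compound 2 all give numbers within the scatter of one another. The gap to compound 1 persists with this new group, as the step of a 4.0-fold higher number from compound 1 to compound 4 (0.60 log units; beyond the scatter) lies beyond the scatter, so among these four compounds the exchange on the saturated ring carbon separates values, while the exchanges on the chain carbon do not. Nothing measured here explains these results.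

The compounds shown leave open whether a carboxylic acid or a primary amine on this chain carbon would also stay within the scatter of compound 3. They also leave open whether a plain hydroxy group on the saturated ring carbon would differ from methyl as the ester-bearing groups do.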